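This account rests on a few compounds, and the source may have more. Where it says the series, first, only, none or still open, it means among the compounds named here.

Measured compounds:
- compound 1, `O=C(O)[C@@H]1CCCN1C(=O)/C=C/c1ccncc1-c1ccc2ccccc2c1`: "not determined" (no result reported) in an assay on a protein complex for inhibition of CDK8/Cyclin C (Homo sapiens), with a stated time of 1 h; a higher number here means a weaker inhibitor, a lower number a stronger inhibitor
- compound 2, `CNC(=O)CCc1ccncc1-c1ccc2ccccc2c1`: 21.1 nM

Among the measured compounds shown here, compound 2 is the only compound of this pair with a number: in this assay compound 2 gives 21.1 nM, while compound 1 carries no result at all, so it cannot be placed on the scale. For the measured compounds named here, nothing beyond that single number is available, and no measured step between two related compounds exists here.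

Compound 3 is `COC(=O)CCc1ccncc1-c1ccc2ccccc2c1`. Compared with compound 2, the change is methoxy in place of methylamino on a carbonyl carbon: an ester takes the place of the amide that closes the chain in compound 2, and the single hydrogen-bond donor of that chain is gone. Going by the values given here, no measured pair in this set shows what such a swap does, so any expectation rests on the one value of compound 2 alone. A modest weakening is expected for compound 3, a step of a 2.8-fold higher number from compound 2 to compound 3 (0.45 log units; beyond the scatter) that lies only a little beyond the usual scatter and could fall inside it. Compound 3 is therefore expected to give about 60 nM in this assay, within a range from 15 nM to 300 nM.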

Compound 3, half-maximal inhibitory concentration: 259 nM
Estimate against measurement, compound 3: 4.3-fold (0.64 log units) below; the range from low to high includes it.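

Among the compounds shown here, the swap of methylamino for methoxy on a carbonyl carbon gives a 12-fold higher number from compound 2 to compound 3 (1.09 log units; beyond the scatter) in this assay, so this is the first measured sign that the end of the chain matters to this inhibition. The change is small on paper: each group has 2 heavy atoms, no ring and no net charge, and the core and the rest of the chain stay the same. Even so, the ester, compound 3, is a clearly weaker inhibitor than the amide, compound 2, which shows that a nitrogen-to-oxygen exchange at this one place can cost far more than repeat measurements would scatter. Nothing shown explains why the number rises this far.

The loss of the amide hydrogen and the exchange of nitrogen for oxygen happen together in this one step, so the two compounds cannot separate them; a dimethylamino group on the same carbonyl carbon, which keeps the nitrogen but has no amide hydrogen, would pull them apart. Also open, on these data alone, is whether a plain amino or a larger ethylamino group there would match or improve on compound 2.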